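Methoxy to Ethoxy: No Gain Expected in Growth Inhibition

The compounds below may be only part of what the source reports. "The series", "measured", "known", "first", "only" and "open" are said of these compounds alone.

Measured compounds:
Compound 1, `Cc1cc(=O)oc2cc(SCc3ccccn3)ccc12`: in a functional assay on DU-145 cells (Homo sapiens) for antiproliferative activity, read by sulforhodamine B assay, with a stated time of 72 h (a lower number here means a stronger inhibitor of growth, a higher number a weaker inhibitor of growth), compound 1 gives > 35200 nM, a limit of the assay.
Compound 2, `CCc1oc2c(C)c(OCc3cccc(C(F)(F)F)c3)ccc2c(=O)c1Br`: compound 2 gives > 22600 nM, again a limit.
Compound 3, `CCc1cc(=O)c2ccc(OC)c(CBr)c2o1`: compound 3 gives > 33600 nM, likewise a limit.

Compound 3 thus stands nowhere in particular among these numbers: its value is only a limit of this assay, and the two other values are limits as well, so no measured step separates any pair of them. All three sit at the top of what the assay reports, as the lines (the limit of > 22600 nM in this assay, at which 1 of the 3 values shown sits), the limit of > 33600 nM in this assay, at which 1 of the 3 values shown sits, and the limit of > 35200 nM in this assay, at which 1 of the 3 values shown sits, show, one compound at each limit.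

Compound 4, `CCOc1ccc2c(=O)cc(CC)oc2c1CBr`, differs from compound 3 by methyl in place of hydrogen on a saturated chain carbon bound to an oxygen on an aromatic ring. Put more simply, a methoxy group becomes an ethoxy group. Among the compounds with values here, no step between measured compounds is available to gauge this change. Since compound 3 already reaches only a limit, the change from compound 3 to compound 4 is expected to produce no step beyond the scatter, a step that the limit leaves unreadable from compound 3 to compound 4. Compound 4 is therefore estimated at 40000 nM, within 10000 nM to 150000 nM, most likely reported as another limit.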

Compound 4, concentration for 50% growth inhibition: > 32100 nM
Compound 4 ended at the assay's limit; the forecaster's own chance of this, stated with the estimate: 80%; the middle value does not contradict the limit.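

In this assay compound 3 gives > 33600 nM, a limit. Within the data shown here, compound 4 gives > 32100 nM, also a limit, so no step between compound 3 and compound 4 can be read. The compounds shown leave open whether methoxy to ethoxy changes growth inhibition at all.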